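Adding fluoro to the phenylsulfonyl group of the series

The source may report more compounds than this note shows. Statements on the series, on what has been measured and on what is new or still open speak of the compounds shown alone.

In an ADME assay on L02 cells (Homo sapiens) for cytotoxicity, read by MTT assay, with a stated time of 24 h (a lower number here means a stronger inhibitor, a higher number a weaker inhibitor), compound 3 `O=C1/C(=C/c2cccnc2)CN(S(=O)(=O)c2ccccc2)C/C1=C\c1ccccc1C(F)(F)F` gives 12500 nM and sits within the scatter of both other measured compounds. Compound 2 `O=C1/C(=C/c2cccnc2)CN(S(=O)(=O)c2ccccc2)C/C1=C\c1ccccc1F` gives 15300 nM and compound 1 `COc1cc(/C=C2\CN(C)C/C(=C\c3ccncc3)C2=O)cc(OC)c1OC` gives 16400 nM for comparison.

Compound 4 `O=C1/C(=C/c2cccnc2)CN(S(=O)(=O)c2ccc(F)cc2)C/C1=C\c1ccccc1C(F)(F)F` keeps compound 3 intact except that phenylsulfonyl becomes (4-fluorophenyl)sulfonyl, with fluoro in place of hydrogen on an aromatic carbon.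

Going by the values given here, only one measured step bears on this, and only indirectly: a 1.2-fold lower number from compound 2 to compound 3 (0.09 log units; within the scatter). That step swaps trifluoromethyl for fluoro elsewhere in the molecule. Among the compounds with values here, no measured pair shows a change on the phenylsulfonyl group itself, so the data offer no sign of a large shift in this assay. The expected change is a 1.0-fold lower number from compound 3 to compound 4 (0.02 log units; within the scatter), which means no expected movement beyond the scatter. Compound 4 is estimated at 12000 nM, with an expected range from 6500 nM to 22000 nM.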

Compound 4, half-maximal inhibitory concentration: 16100 nM
Estimate against measurement, compound 4: 1.3-fold (0.13 log units) below; the measured number falls inside the stated range.
By their numbers in this assay, from the lowest: compounds 3, 2, 4 and 1 (each within the scatter of the next).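

This is the only step on the phenylsulfonyl group among the compounds shown: in this assay, fluoro in place of hydrogen on an aromatic carbon, para to a large group, reads as a 1.3-fold higher number from compound 3 to compound 4 (0.11 log units; within the scatter). The earlier step, a 1.2-fold lower number from compound 2 to compound 3 (0.09 log units; within the scatter), concerned a change elsewhere in the molecule and said nothing directly about this position, which now tolerates fluoro without a shift beyond the scatter. No supporting data bear on this result.

From the compounds shown here alone, how a methoxy group, an amine or a carboxylic acid at this position would read in this assay remains open. Also open, going by these compounds, is whether fluoro here gives the same result when the other aromatic ring carries fluoro rather than trifluoromethyl.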